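Halogen for isopropyl on the aryl ring of compound 3

This account rests on a few compounds, and the source may have more. Where it says the series, first, only, none or still open, it means among the compounds named here.

Measured so far:
compound 1 `CC(C)c1ccc(-c2nc(SCc3cn(CC(=O)NC(=O)Nc4ccccn4)nn3)nc(Nc3ccc(Cl)cc3)c2C#N)cc1` gives > 64000 nM in a functional assay on MCF7 cells (Homo sapiens) for inhibition, read by MTT assay, with a stated time of 72 h (on this read-out higher numbers stand for weaker inhibition and lower numbers for stronger inhibition), a limit of the assay and not a number.
compound 2 `CC(C)c1ccc(-c2nc(SCc3cn(CC(=O)NC(=O)Nc4ccccn4)nn3)nc(Nc3ccccc3F)c2C#N)cc1` gives > 64000 nM in this assay, again a limit of the assay.
compound 3 `CC(C)c1ccc(Nc2nc(SCc3cn(CC(=O)NC(=O)Nc4ccccn4)nn3)nc(-c3ccc(C(C)C)cc3)c2C#N)cc1` gives 28600 nM in this assay.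

Within the data shown here, compound 3 thus holds the only number in the set; the other two values sit at the limit of > 64000 nM in this assay, at which 2 of the 3 values shown sit. Compound 4 `CC(C)c1ccc(Nc2nc(SCc3cn(CC(=O)NC(=O)Nc4ccccn4)nn3)nc(-c3ccc(Br)cc3)c2C#N)cc1` differs from compound 3 by bromo in place of isopropyl on an aromatic carbon.

Among the measured compounds shown here, only one measured step bears on this change: an at least 2.2-fold lower number from compound 1 to compound 3 (0.34 log units; beyond the scatter), where isopropyl replaced a halogen on an aromatic carbon and the number fell. The step to compound 4 runs the other way, a halogen replacing isopropyl, though on the other aryl ring. Compound 2 and compound 3 give an at least 2.2-fold lower number from compound 2 to compound 3 (0.34 log units; beyond the scatter), but this alters the whole group on the nitrogen and is less comparable.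

The step from compound 3 to compound 4 is therefore expected to raise the number, estimated as a 2.1-fold higher number from compound 3 to compound 4 (0.32 log units; beyond the scatter), with a fair chance that the assay reports only a limit. Compound 4 is expected to give about 60000 nM, in the range 25000 nM to 150000 nM.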

Compound 4, half-maximal inhibitory concentration: 30600 nM
For compound 4 the middle estimate is 2.0-fold (0.29 log units) above the measured one, and the stated range covers the measured number.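

In this assay, the ring position para to a large group tolerates the exchange of isopropyl for bromo: a 1.1-fold higher number from compound 3 to compound 4 (0.03 log units; within the scatter), so three carbons give way to one bromine with no readable change. The ring on the nitrogen gives a different picture, with isopropyl in place of chloro there producing an at least 2.2-fold lower number from compound 1 to compound 3 (0.34 log units; beyond the scatter), so a halogen on one aryl ring cannot be read across to the other. Compound 1 and compound 2 remain at a limit, not a number: the limit of > 64000 nM in this assay, at which 2 of the 4 values shown sit.

On these data alone, whether this flat response holds beyond isopropyl and bromo at this position remains open, for example with an amine or a carboxylic acid there. Also open, as far as these compounds go, is whether a group of this kind on both rings at once would keep the number near that of compound 4.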